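Sulfonyl to Ketone on the Indole Acrylonitrile Chain

This account rests on a few compounds, and the source may have more. Where it says the series, first, only, none or still open, it means among the compounds named here.

Compound 1, `CC(=O)/C(=C\c1c(-c2ccccc2)[nH]c2ccccc12)S(=O)(=O)c1ccccc1`: 778 nM
Compound 2, `COc1ccc2[nH]c(-c3ccccc3)c(/C=C(\C#N)S(=O)(=O)c3ccccc3)c2c1`: 4000 nM
Compound 3, `N#C/C(=C\c1c(-c2ccccc2)[nH]c2ccccc12)S(=O)(=O)c1ccccc1`: 570 nM

All three were tested in a functional assay on SW-620 cells (Homo sapiens) for inhibition, read by sulforhodamine B assay, with a stated time of 48 h; a higher number here means a weaker inhibitor of growth, a lower number a stronger inhibitor of growth. Compound 3 gives the lowest of the three numbers. Its nearest neighbour is compound 1, at 778 nM; the step of a 1.4-fold lower number from compound 1 to compound 3 (0.14 log units; within the scatter) lies within the scatter, so the two cannot be ordered. Compound 2 stands furthest away, and the step of a 7.0-fold lower number from compound 2 to compound 3 (0.85 log units; beyond the scatter) is beyond the scatter.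

Compound 4, `N#C/C(=C\c1c(-c2ccccc2)[nH]c2ccccc12)C(=O)c1ccccc1`, has not been measured. It differs from compound 3 in one place: benzoyl in place of phenylsulfonyl on a double-bonded chain carbon bound to a double-bonded chain carbon and a triple-bonded carbon. Among the compounds with values here, no measured step changes this part of the molecule. Within the data shown here, the only step that touches the chain is that from compound 1 to compound 3, where one group on the other chain carbon was exchanged for another, and that step stayed within the scatter. The ring change seen from compound 2 to compound 3 does not bear on a change at the chain.

With nothing more to go on, compound 4 is expected to fall close to compound 3, with a step of a 1.4-fold higher number from compound 3 to compound 4 (0.15 log units; within the scatter) that should not go beyond the scatter. The estimate for compound 4 in this assay is therefore 800 nM, with a range from 300 nM to 2500 nM.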

Compound 4, concentration for 50% growth inhibition: 3000 nM
Estimate against measurement, compound 4: 3.8-fold (0.57 log units) below, outside the stated range (above it).
By their numbers in this assay, from the lowest: compounds 3 and 1 (each within the scatter of the next); then compounds 4 and 2 (each within the scatter of the next).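

In this assay, within the data shown here, the exchange of phenylsulfonyl for benzoyl gives a 5.3-fold higher number from compound 3 to compound 4 (0.72 log units; beyond the scatter) and so shows that this place on the chain does respond to the group it carries, something the only earlier chain step, a 1.4-fold lower number from compound 1 to compound 3 (0.14 log units; within the scatter) on the other side of the exchange, gave no sign of. Phenylsulfonyl and benzoyl each hold one six-membered aromatic ring of carbon only, so the exchange is confined to the link that joins that ring to the chain, a sulfonyl in compound 3 and a carbonyl in compound 4. Nothing measured here accounts for the size of this step, and no cause can be given for it.

The compounds shown leave open whether the sulfonyl link or the ring on it carries the difference, which a methylsulfonyl group or a sulfonamide at this place would help to separate. They also leave open whether a carboxylic ester or an amide would stand with benzoyl or with phenylsulfonyl, and whether the step would be the same with the methoxy group of compound 2 on the core.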